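The source may report more compounds than this note shows. Statements on the series, on what has been measured and on what is new or still open speak of the compounds shown alone.

Compound 1 `CC(C)Cn1nc(C(=O)N[C@H]2COc3ccccc3N(C)C2=S)nc1Cc1ccccc1` carries an isobutyl group on an aromatic nitrogen of the shared core. In a functional assay on HT-29 cells (Homo sapiens) for inhibition, read by luminescence and CellTiter-Glo, with a stated time of 24 h (a higher number here means that more compound is needed for the effect, a lower number that less compound is needed), compound 1 gives 1230 nM, the lowest of the three numbers in hand, though both others lie within the scatter of it: compound 2 `CN1C(=S)[C@@H](NC(=O)c2nc(Cc3ccccc3)n(CCCC(F)(F)F)n2)COc2ccccc21` gives 2380 nM and compound 3 `CN1C(=S)[C@@H](NC(=O)c2nc(Cc3ccccc3)n(C3CCOC3)n2)COc2ccccc21` gives 1580 nM. The steps of a 1.9-fold higher number from compound 1 to compound 2 (0.29 log units; within the scatter) and a 1.3-fold higher number from compound 1 to compound 3 (0.11 log units; within the scatter) stay within the scatter, as does a 1.5-fold lower number from compound 2 to compound 3 (0.18 log units; within the scatter). Compound 4 `CN1C(=S)[C@@H](NC(=O)c2nc(Cc3ccccc3)n(CC3COC3)n2)COc2ccccc21` differs from compound 1 by oxetan-3-yl in place of isopropyl on a saturated chain carbon bound to an aromatic nitrogen. For the measured compounds named here, the nearest precedent is compound 3, where oxolan-3-yl entered on the aromatic nitrogen and gave a 1.3-fold higher number from compound 1 to compound 3 (0.11 log units; within the scatter); no step in this set exceeds the scatter. Compound 4 is therefore expected to stay close to compound 1, with an estimated step of a 1.2-fold higher number from compound 1 to compound 4 (0.09 log units; within the scatter). The estimate for compound 4 is 1500 nM, with a range from 700 nM to 3500 nM.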

Compound 4, half-maximal effective concentration: 2830 nM
Compound 4: the middle estimate sits 1.9-fold (0.28 log units) below what was measured; low and high end bracket the measured number.
By their numbers in this assay, from the lowest: compounds 1, 3, 2 and 4 (each within the scatter of the next, the first and the last beyond it).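

Going from isobutyl to (oxetan-3-yl)methyl gives a 2.3-fold higher number from compound 1 to compound 4 (0.36 log units; beyond the scatter) in this assay, the first step at this position to pass the scatter, though only a modest one. Compound 4 stays close to the other two, with a 1.8-fold higher number from compound 3 to compound 4 (0.25 log units; within the scatter) and a 1.2-fold higher number from compound 2 to compound 4 (0.08 log units; within the scatter) as its steps, so it separates from compound 1 only and gives no order among compound 2, compound 3 and compound 4. Nothing measured here accounts for the step from the isobutyl group.

Going by these compounds, whether an amine or a carboxylic acid on this chain would move the number further, and in which direction, stays open.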